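Extending the Ring Amine of Compound 3

The source may report more compounds than this note shows. Statements on the series, on what has been measured and on what is new or still open speak of the compounds shown alone.

Compound 1 `Cn1c(-c2ccc(NC(=O)CCl)cc2)nc(-c2ccccc2)c1-c1ccccc1` gives 15.1% in a functional assay on HT-29 cells (Homo sapiens) for cytotoxicity, read by MTT assay, with a stated time of 24 h, tested at 6.4 ug/mL; a higher number here means a stronger effect of the compound at the concentration tested, a lower number a weaker effect. Compound 2 `Cn1c(-c2ccc(NC(=O)CSc3nc4cc(Cl)ccc4o3)cc2)nc(-c2ccccc2)c1-c1ccccc1` gives 29.4%. Compound 3 `CN1CCN(CC(=O)Nc2ccc(-c3nc(-c4ccccc4)c(-c4ccccc4)n3C)cc2)CC1` gives 28.8%.

Compound 3 stands second highest of the three: a number 0.6 percentage points lower from compound 2 to compound 3 (within the scatter), whereas a number 13.7 percentage points higher from compound 1 to compound 3 (beyond the scatter). Compound 4 `CN(C)/C=C/N1CCN(CC(=O)Nc2ccc(-c3nc(-c4ccccc4)c(-c4ccccc4)n3C)cc2)CC1` differs from compound 3 in one place: 2-(dimethylamino)ethenyl in place of methyl on an amine nitrogen in a ring. Within the data shown here, neither measured step touches this ring nitrogen; both a number 14.3 percentage points higher from compound 1 to compound 2 (beyond the scatter) and a number 13.7 percentage points higher from compound 1 to compound 3 (beyond the scatter) concern replacement of chloro on the chain carbon bound to the carbonyl, so no step bears directly on the change. With no evidence either way, compound 4 is expected to show no step beyond the scatter, a number 0.2 percentage points higher from compound 3 to compound 4 (within the scatter). Compound 4 is therefore estimated at 29%, within 15% to 45% in this assay.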

Compound 4, a percentage reported as activity, at one concentration (the size of the read-out at that concentration, not a potency): 12.2%
The estimate for compound 4 lay 16.8 percentage points above the measured number, outside the stated range (below it).
By their numbers in this assay, from the lowest: compounds 4 and 1 (each within the scatter of the next); then compounds 3 and 2 (each within the scatter of the next).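

In this assay the amine nitrogen in the ring proves sensitive to change, since with 2-(dimethylamino)ethenyl in place of methyl there is a number 16.6 percentage points lower from compound 3 to compound 4 (beyond the scatter). The gain seen for 4-methylpiperazin-1-yl over chloro does not carry over to the extended group, with a number 2.9 percentage points lower from compound 1 to compound 4 (within the scatter) and a number 17.2 percentage points lower from compound 2 to compound 4 (beyond the scatter). Nothing available accounts for this drop.

From the compounds shown here alone, whether it follows from the added chain length, the double bond or the second amine stays open. An ethyl group or a saturated 2-(dimethylamino)ethyl chain on the same nitrogen would separate these.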